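The compounds below may be only part of what the source reports. "The series", "measured", "known", "first", "only" and "open" are said of these compounds alone.

Measured compounds:
Compound 1, `CN1CCN(CC(=O)Nc2ccc(-c3nc4cc(C(F)(F)F)ccc4n3C)cc2)CC1`, in an ADME assay on BHK cells (Mesocricetus auratus) for cytotoxicity, read by MTT assay, with a stated time of 96 h (on this read-out higher numbers stand for lower toxicity in this test and lower numbers for higher toxicity in this test), compound 1 gives 16000 nM.
Compound 2, `Cn1c(-c2ccc(NC(=O)CN3CCCC3)cc2)nc2cc(C(F)(F)F)ccc21`, in this assay compound 2 gives 27000 nM.

Going by the values given here, compound 2 holds the higher of the two numbers recorded so far, but its nearest neighbour is compound 1, and the only step between measured compounds is a 1.7-fold higher number from compound 1 to compound 2 (0.23 log units; within the scatter), so the two compounds cannot be ordered on this read-out.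

Compound 3 is `CC(=O)Nc1ccc(-c2nc3cc(C(F)(F)F)ccc3n2C)cc1` and awaits measurement. It differs from compound 2 by hydrogen in place of pyrrolidin-1-yl on a saturated chain carbon bound to a carbonyl carbon. Among the compounds with values here, no measured step removes the pyrrolidin-1-yl group altogether; the single step on record, from compound 1 to compound 2, exchanges one saturated nitrogen ring for another and stays within the scatter. That step therefore gives only indirect support: it shows that a change on the saturated chain carbon bound to the carbonyl carbon left the number essentially where it was. On this basis no movement beyond the scatter is expected for compound 3, with the direction left open. Compound 3 is estimated at 25000 nM, with a range from 8000 nM to 80000 nM. The expected step is a 1.1-fold lower number from compound 2 to compound 3 (0.03 log units; within the scatter).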

Compound 3, half-maximal cytotoxic concentration: > 100000 nM
Compound 3 gave a limit, no number; the forecaster's own chance of this, stated with the estimate: 25%; middle value at least 4.0-fold (0.60 log units) from the limit.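

In this assay, the place on a saturated chain carbon bound to a carbonyl carbon turns out not to be indifferent: the exchange of one saturated nitrogen ring for another gave a 1.7-fold higher number from compound 1 to compound 2 (0.23 log units; within the scatter), whereas hydrogen in place of pyrrolidin-1-yl gave an at least 3.7-fold higher number from compound 2 to compound 3 (0.56 log units; beyond the scatter), and hydrogen in place of 4-methylpiperazin-1-yl gave an at least 6.2-fold higher number from compound 1 to compound 3 (0.79 log units; beyond the scatter). For compound 3 the result is a limit of the assay and not a number: the limit of > 100000 nM in this assay, at which 1 of the 3 values shown sits. Among these three compounds, the line on this read-out therefore falls between having one of the two rings on that carbon and having none, not between the two rings, and the acetamido compound, compound 3, stands on the side of lower toxicity in this test.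

On these data alone, whether an open-chain dimethylamino group, a morpholin-4-yl ring or a carboxylic acid on that carbon would fall with compound 1 and compound 2 or with compound 3 stays open. Also open, as far as these compounds go, are how far compound 3 lies past its limit and whether the same change would give a similar step on a different core.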